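The source may report more compounds than this note shows. Statements on the series, on what has been measured and on what is new or still open speak of the compounds shown alone.

Measured in a functional assay on SMMC-7721 cells (Homo sapiens) for antiproliferative activity, read by MTT assay, with a stated time of 48 h; on this read-out higher numbers stand for weaker inhibition and lower numbers for stronger inhibition:
- compound 1 `Cn1cc(C2=C(c3nn(CCCN4CCCCC4)c4ncccc34)C(=O)N(c3ccccc3)C2=O)c2ccccc21`: 3050 nM
- compound 2 `Cn1cc(C2=C(c3nn(CCCn4cccc4)c4ncccc34)C(=O)NC2=O)c2ccccc21`: > 100000 nM (a limit, not a number)

Compound 2 has no numerical value and stands at a limit: the limit of > 100000 nM in this assay, at which 1 of the 2 values shown sits.

Compound 3 `Cn1cc(C2=C(c3nn(CCCn4cccc4)c4ncccc34)C(=O)N(c3ccccc3)C2=O)c2ccccc21`, not yet measured, differs from compound 2 by phenyl in place of hydrogen on an amide-type nitrogen in a ring.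

Among the compounds with values here, no measured step isolates this change, so the expectation rests on one indirect comparison. Compound 1, at 3050 nM, carries the same phenyl on that nitrogen, although the end of its propyl chain differs from that of compound 3. A step toward stronger inhibition in this assay, well beyond the scatter, is therefore expected: an at least 12-fold lower number from compound 2 to compound 3 (1.09 log units; beyond the scatter).

For compound 3, the estimated value is 8000 nM, with an expected range of 1500 nM to 40000 nM.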

Compound 3, half-maximal inhibitory concentration: > 100000 nM
Compound 3: no number, only a limit (the forecaster's own chance of this, stated with the estimate: 15%); at least 12-fold (1.09 log units) between middle value and limit.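

Phenyl on the amide-type nitrogen does not bring compound 3 off the limit: in this assay, compound 3 gives > 100000 nM, a limit and not a number. The step between compound 2 and compound 3 cannot be read, as both ends are limits: the limit of > 100000 nM in this assay, at which 2 of the 3 values shown sit.

With phenyl held on that nitrogen, 1H-pyrrol-1-yl in place of piperidin-1-yl on the propyl chain gives an at least 32-fold higher number from compound 1 to compound 3 (1.51 log units; beyond the scatter), so in this pair the measurable inhibition goes with the piperidin-1-yl end and phenyl alone does not carry it.

Open, going by these compounds, is whether phenyl matters once the chain ends in piperidin-1-yl, a question for the partner of compound 1 carrying the amide hydrogen. Also open, on these data alone, is whether another amine at the chain end, such as morpholin-4-yl or dimethylamino, keeps the inhibition of compound 1.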